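The source may report more compounds than this note shows. Statements on the series, on what has been measured and on what is new or still open speak of the compounds shown alone.

Compound 1 `O=C(CCCCCc1ccc(F)c(Cl)c1)N1CCOC1=O` gives 26 nM in an assay on HEK293 cells for inhibition of N-acylethanolamine-hydrolyzing acid amidase (Rattus norvegicus), read by LC-MS, with a stated time of 30 min; on this read-out higher numbers stand for weaker inhibition and lower numbers for stronger inhibition.
Compound 2 `O=C(CCCCCc1ccc(O)c(Cl)c1)N1CCOC1=O` gives only the limit > 20000 nM in this assay.

In this assay compound 2 stands at the limit of > 20000 nM in this assay, at which 1 of the 2 values shown sits, so no number of its own is known for it. Compound 3 `O=C(CCCCCc1ccc(O)c(F)c1)N1CCOC1=O` differs from it by fluoro in place of chloro on an aromatic carbon. For the measured compounds named here, the one measured step, an at least 760-fold higher number from compound 1 to compound 2 (2.88 log units; beyond the scatter), concerns the entry of hydroxy rather than a swap between halogens, so it does not bear on this change. With nothing measured pointing either way, compound 3 is expected to stay close to the limit, a step that the limit leaves unreadable from compound 2 to compound 3. The estimate for compound 3 is 25000 nM, between 5000 nM and 100000 nM.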

Compound 3, half-maximal inhibitory concentration: 160 nM
Compound 3: the middle estimate sits 160-fold (2.19 log units) above what was measured, outside the stated range (below it).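

In this assay, fluoro in place of chloro on this aromatic carbon, ortho to a hydroxy group, gives an at least 120-fold lower number from compound 2 to compound 3 (2.09 log units; beyond the scatter), so the choice of halogen here matters strongly. The hydroxy group therefore does not by itself end inhibition, since compound 3 carries it and gives 160 nM in this series. Compound 2 stands at a limit of the assay, not at a number, so the step has no upper size: the limit of > 20000 nM in this assay, at which 1 of the 3 values shown sits. Open, from the compounds shown here alone, is how a bromo or methyl group on this carbon would compare with fluoro and chloro. Also open, going by these compounds, is whether the effect of fluoro would hold with a longer chain.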